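The source may report more compounds than this note shows. Statements on the series, on what has been measured and on what is new or still open speak of the compounds shown alone.

Measured so far in a functional assay on PC-3 cells (Homo sapiens) for cytotoxicity, read by WST assay, with a stated time of 72 h; a lower number here means a stronger inhibitor, a higher number a weaker inhibitor:
- Compound 1 `CCCC1(c2ccc(O)cc2)C(=O)Nc2c1ccc(F)c2F`: > 1000 nM (a limit of the assay, not a number)
- Compound 2 `CCCCCC1(c2ccc(O)cc2)C(=O)Nc2c1ccc(F)c2F`: 1.1 nM

Among the compounds with values here, compound 2 holds the only true number so far, so it has no measured neighbour to be ranked against except a limit. Compound 3 `O=C1Nc2c(ccc(F)c2F)C1(c1ccc(O)cc1)C1CCCC1` changes it in one place: cyclopentyl in place of pentyl on a saturated ring carbon. The pentyl chain gives way to a cyclopentyl ring on the same saturated ring carbon.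

Within the data shown here, one measured step bears on this: an at least 900-fold lower number from compound 1 to compound 2 (2.95 log units; beyond the scatter). That step is large and beyond the scatter, and it came from a change in the chain alone, so the group at this spot can move the number a long way in this assay. Among the measured compounds shown here, no measured pair compares a ring with a chain, which leaves the size of the next step open. Compound 3 loses the pentyl chain of compound 2, so a clear rise in the number, meaning a weaker compound, is expected, though probably not all the way to the limit.

The estimated change is a 23-fold higher number from compound 2 to compound 3 (1.36 log units; beyond the scatter). For compound 3 the expected value is 25 nM, with an estimated range from 2 nM to 300 nM.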

Compound 3, half-maximal inhibitory concentration: 8.2 nM
Compound 3: middle estimate off by 3.0-fold (0.48 log units), on the high side, and the stated range covers the measured number.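

In this assay, a ring can stand on this saturated ring carbon without much loss: replacing the open pentyl chain with cyclopentyl, which has the same count of 5 carbon atoms, gives a 7.5-fold higher number from compound 2 to compound 3 (0.87 log units; beyond the scatter). That step is modest, although it lies beyond the usual scatter, and the earlier pair could not show this because it compared only chains. The large difference from the propyl compound also survives when the group is a ring, with an at least 120-fold lower number from compound 1 to compound 3 (2.08 log units; beyond the scatter), so a strong number at this spot does not depend on an open chain. Compound 1 holds a limit of the assay and not a number: the limit of > 1000 nM in this assay, at which 1 of the 3 values shown sits.

The compounds shown leave open how a smaller ring such as cyclopropyl, a larger ring such as cyclohexyl or a longer chain such as heptyl would read at this carbon. They also leave open whether a ring containing nitrogen, such as piperidine, would keep the number close to that of compound 3, and whether the gap between pentyl and cyclopentyl would stay this modest on a different core.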